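Cyclohexyl for phenyl on the amide nitrogen, compound 3

The compounds below may be only part of what the source reports. "The series", "measured", "known", "first", "only" and "open" are said of these compounds alone.

Compound 1 `C#CCn1cc(C(=O)NC(CC(=O)Nc2ccccc2)c2ccccc2)c(=O)c2cc(F)c(Cl)nc21` in a functional assay on ECV-304 cells (Homo sapiens) for cytotoxicity, read by MTT assay, with a stated time of 72 h (a higher number here means a weaker inhibitor, a lower number a stronger inhibitor), gives > 10000 nM, a limit of the assay.
Compound 2 `C#CCn1cc(C(=O)NC(CC(=O)Nc2ccccn2)c2ccccc2)c(=O)c2ccc(Cl)nc21` in this assay gives > 10000 nM, also a limit of the assay.

Compound 1 stands at the limit of this assay; no number is known for it. Among the compounds with values here, the same holds for compound 2, so both values shown sit at the limit of > 10000 nM in this assay, at which 2 of the 2 values shown sit, and no step between measured compounds can be drawn from them.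

Compound 3 `C#CCn1cc(C(=O)NC(CC(=O)NC2CCCCC2)c2ccccc2)c(=O)c2cc(F)c(Cl)nc21` is not yet measured. From compound 1 it differs by cyclohexyl in place of phenyl on an amide-type nitrogen, the anilino becoming cyclohexylamino.

With both measured compounds at the limit, no step size can be read from the series. The step from compound 1 to compound 3 is expected to be a step that the limit leaves unreadable from compound 1 to compound 3, most likely none beyond the scatter. Compound 3 is therefore expected to give about 20000 nM in this assay, within 5000 nM to 80000 nM, and most probably again to come out as a limit rather than a number.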

Compound 3, half-maximal inhibitory concentration: 9800 nM
Beside the measured number, compound 3's estimate is 2.0-fold (0.31 log units) above it; low and high end bracket the measured number.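

In this assay, within the data shown here, compound 3 gives 9800 nM, the first actual number. Compound 1 gives > 10000 nM, a limit of the assay. Cyclohexyl in place of phenyl on an amide-type nitrogen brings an at least 1.0-fold lower number from compound 1 to compound 3 (0.00 log units; that floor lies within the scatter), so this position accepts a non-aromatic ring of carbon only and still gives a readable value, but the change has no established effect on the number.

On these data alone, the series remains anchored mostly at one edge of the measurable range: the limit of > 10000 nM in this assay, at which 2 of the 3 values shown sit. Still open are the true value of compound 1 and how the number moves with a small group such as methyl, a basic amine or a carboxylic acid on the same amide-type nitrogen.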